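Removing one bromo from compound 1

A few compounds are considered here, and "the series" means these few. Any claim that something is new, unique, unknown or untested is made for them only; others in the source may bear on it.

In an ADME assay on HEK293 cells (Homo sapiens) for cytotoxicity, read by reporter gene assay and resazurin assay, with a stated time of 48 h (a lower number here means that less compound is tolerated, a higher number that more compound is tolerated), compound 1 (`O=C(Nc1cccc(Cl)c1)c1cc(Br)cc(Br)c1O`) gives 18000 nM and compound 2 (`O=C(Nc1ccccc1)c1cc(Br)cc(Br)c1O`) gives 34000 nM, and these two numbers sit together within the scatter. Compound 3 (`COc1c(Br)cc(Br)cc1C(=O)Nc1cccc(Cl)c1`) reads > 100000 nM, which is a limit of the assay. Compound 4 (`O=C(Nc1cccc(Cl)c1)c1cccc(Br)c1O`) departs from compound 1 by hydrogen in place of bromo on an aromatic carbon. The closest measured change, also a halogen giving way to hydrogen, is a 1.9-fold higher number from compound 1 to compound 2 (0.28 log units; within the scatter). The change on the oxygen, an at least 5.5-fold higher number from compound 1 to compound 3 (0.74 log units; beyond the scatter), is larger but lies elsewhere and bears little on this one. The expected move in this assay is therefore small, upward if anything, and inside the scatter, resting on a 1.9-fold higher number from compound 1 to compound 2 (0.28 log units; within the scatter). The estimated step is a 1.7-fold higher number from compound 1 to compound 4 (0.22 log units; within the scatter). Compound 4 is estimated at 30000 nM, with an expected range of 12000 nM to 70000 nM.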

Compound 4, half-maximal cytotoxic concentration: 32000 nM
Estimate against measurement, compound 4: 1.1-fold (0.03 log units) below; the measured number falls inside the stated range.
By their numbers in this assay, from the lowest: compounds 1, 4 and 2 (each within the scatter of the next). At a limit, above all of these: compound 3.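

On the aromatic carbon para to a hydroxy group, hydrogen in place of bromo gives a 1.8-fold higher number from compound 1 to compound 4 (0.25 log units; within the scatter) and so leaves the number in this assay within the scatter. Among the compounds shown here, the earlier steps touched only the chloro and the oxygen, so this is the first reading on a bromo of the shared core. Both compounds of this step read as numbers, and only compound 3 stands at a limit: the limit of > 100000 nM in this assay, at which 1 of the 4 values shown sits.

From the compounds shown here alone, whether an amine or a carboxylic acid on this carbon would shift the number stays open. So does the loss of the other bromo.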